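The source may hold more compounds than are shown below. What is called first, only, known or untested is meant among the compounds shown, and "the series" means these compounds.

Measured compounds and their values in a functional assay on Caco-2 cells (Homo sapiens) for activation, read by fluorescence, tested at 1 uM; on this read-out higher numbers stand for a weaker effect at the one concentration tested and lower numbers for a stronger effect:

compound 1 `COc1cc(/C=C/C(=O)/C=C(/C=C/c2ccc(O)c(OC)c2)NCCO)ccc1O`: 103%
compound 2 `COc1cc(/C=C/C(=O)/C=C(/C=C/c2ccc(O)c(OC)c2)NCCCO)ccc1O`: 93.4%
compound 3 `COCCNC(=C\C(=O)/C=C/c1ccc(O)c(OC)c1)/C=C/c1ccc(O)c(OC)c1`: 105%

Among these three, compound 3 gives the highest number in this assay , so its effect at the single concentration is on the weak side. Its nearest neighbour is compound 1, with a gap of a number 2 percentage points higher from compound 1 to compound 3 (within the scatter), which stays within the scatter; the widest gap is to compound 2, a number 11.6 percentage points higher from compound 2 to compound 3 (beyond the scatter), which lies beyond it.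

Compound 4 `COCCCNC(=C\C(=O)/C=C/c1ccc(O)c(OC)c1)/C=C/c1ccc(O)c(OC)c1` differs from compound 3 by methoxymethyl in place of methoxy on a saturated chain carbon, two bonds along the chain from an amine nitrogen. The measured step that most resembles this one is the lengthening of the chain from compound 1 to compound 2, which gave a number 9.6 percentage points lower from compound 1 to compound 2 (within the scatter) and so stayed within the scatter. On that basis the step of a number 5 percentage points lower from compound 3 to compound 4 (within the scatter) is expected to be small, with no direction beyond the scatter. Compound 4 is therefore estimated at 100% in this assay , with a likely range from 88% to 114%.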

Compound 4, a percentage reported as activity, at one concentration (the size of the read-out at that concentration, not a potency): 97.9%
Estimate against measurement, compound 4: 2.1 percentage points above; the range from low to high includes it.
By their numbers in this assay, from the lowest: compounds 2, 4, 1 and 3 (each within the scatter of the next, the first and the last beyond it).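

In this assay, the methoxymethyl for methoxy change on this saturated chain carbon gives a number 7.1 percentage points lower from compound 3 to compound 4 (within the scatter), and the same group in place of the hydroxy gives a number 5.1 percentage points lower from compound 1 to compound 4 (within the scatter), so neither change moves the number past the usual scatter. Compound 4 also completes a second pair for methyl in place of hydrogen on the chain oxygen, with a number 4.5 percentage points higher from compound 2 to compound 4 (within the scatter). That change can now be compared on two chain lengths, and it reads alike on both: the same change on two cores in this assay, a number 2 percentage points higher (within the scatter) from compound 1 to compound 3 and a number 4.5 percentage points higher (within the scatter) from compound 2 to compound 4, 2.5 percentage points apart, within the scatter of two such steps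

Still open, on these data alone, is whether a different end group on this chain, such as an amine or a carboxylic acid, or a chain longer than 3-methoxypropyl, would shift the number beyond the scatter. With a single tested concentration, these numbers also say nothing about potency.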